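Estimating Cytotoxicity After Adding One Methoxy Group

This account rests on a few compounds, and the source may have more. Where it says the series, first, only, none or still open, it means among the compounds named here.

Compound 1 `Cc1n[nH]c2c1[C@@H](c1ccc(OCc3ccc(Cl)cc3)cc1)S[C@@H](C)C(=O)N2` gives "not determined" (no result reported)
Compound 2 `Cc1n[nH]c2c1[C@@H](c1ccc(OCc3cccc(F)c3)cc1)S[C@@H](C)C(=O)N2` gives 103000 nM

These results come from an ADME assay on L929 cells (Mus musculus) for cytotoxicity, read by microscopy, with a stated time of 96 h (on this read-out higher numbers stand for lower toxicity in this test and lower numbers for higher toxicity in this test), and they offer no firm starting point. Going by these compounds, compound 1 has no single number in this test, so its place on the scale is unknown. Within the data shown here, the only measured neighbour is compound 2, a close relative that carries a different halogen on its benzyl group.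

Compound 3 `COc1cc([C@H]2S[C@@H](C)C(=O)Nc3[nH]nc(C)c32)ccc1OCc1ccc(Cl)cc1` has not yet been measured. It is reached by one structural change, methoxy in place of hydrogen on an aromatic carbon (methoxy in place of hydrogen on an aromatic carbon, ortho to a (4-chlorobenzyl)oxy group). Among the measured compounds shown here, no measured pair here shows what such a change does, so no step beyond the usual scatter is expected in this assay and no direction can be favoured. The expectation therefore leans on compound 2 at 103000 nM with a wide margin, since the starting compound offers no number. For compound 3 the estimated value is 100000 nM with an expected range from 35000 nM to 280000 nM.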

Compound 3, concentration lethal to 50% of the cells: 50600 nM
For compound 3 the middle estimate is 2.0-fold (0.30 log units) above the measured one; measured number inside the range.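

Among these compounds, compound 1 has no single number in this assay, so no step from it to compound 3 can be read. The compounds shown leave open what methoxy in place of hydrogen on an aromatic carbon does to the result in this assay. Nothing shown offers an explanation for the value of compound 3.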